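The source may report more compounds than this note shows. Statements on the series, on what has been measured and on what is new or still open speak of the compounds shown alone.

Compound 3, `COc1ccc(/C=C/C(=O)Nc2cc(C(=O)c3cc(OC)c(OC)c(OC)c3)cc(OC)c2OC)cc1OC`, sits in the middle of three compounds measured in a functional assay on B16 cells (Mus musculus) for cytotoxicity, read by MTT assay, with a stated time of 72 h; on this read-out higher numbers stand for weaker inhibition and lower numbers for stronger inhibition: compound 3 gives 1300 nM, while compound 1, `COc1cccc(/C=C/C(=O)Nc2cc(OC)c(OC)c(OC)c2)c1`, gives 8500 nM, a higher number beyond the scatter, and compound 2, `COc1ccc(C(=O)c2cc(OC)c(OC)c(OC)c2)cc1NC(=O)/C=C/c1ccc(C(F)(F)F)cc1`, gives 100 nM, a lower number also beyond the scatter. Compound 4, `COc1cc(C(=O)c2cc(OC)c(OC)c(OC)c2)cc(NC(=O)/C=C/c2cc(F)c(F)c(F)c2)c1OC`, has not yet been measured. It differs from compound 3 in one place: 3,4,5-trifluorophenyl in place of 3,4-dimethoxyphenyl on a double-bonded chain carbon bound to a double-bonded chain carbon. Among the compounds with values here, no pair of measured compounds differs in only this place, so the size of the step can only be guessed. The guess leans toward a lower number, partly because compound 2 gives 100 nM with a fluorine-bearing ring on the cinnamamide, though compound 2 differs from compound 3 in other places as well. On this basis the step from compound 3 to compound 4 is expected to be a 2.6-fold lower number from compound 3 to compound 4 (0.41 log units; beyond the scatter) in this assay, a moderate improvement. Compound 4 is therefore estimated to give about 500 nM in this assay, within a range from 150 nM to 2500 nM.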

Compound 4, half-maximal inhibitory concentration: 5200 nM
Estimate against measurement, compound 4: 10-fold (1.02 log units) below; measured number outside the range, above it.
By their numbers in this assay, from the lowest: compound 2; then compound 3; then compounds 4 and 1 (each within the scatter of the next).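

In this assay, the exchange of 3,4-dimethoxyphenyl for 3,4,5-trifluorophenyl, on a double-bonded chain carbon bound to a double-bonded chain carbon, gives a 4.0-fold higher number from compound 3 to compound 4 (0.60 log units; beyond the scatter), so at this place the change weakens inhibition. Within the data shown here, the earlier compounds included no pair differing only here, and this step is the first direct reading of the change, though it rests on this single pair. Nothing available explains the direction of the step.

The compounds shown leave open how this place responds to a plain phenyl, a 3,4-dihydroxyphenyl or a ring carrying an amine, and so whether the step follows the loss of the methoxy groups or the entry of the fluorines. They also leave open whether the same exchange would run the same way on the core of compound 2.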